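Swapping an Aryl for a Cyanobenzyl on an Aromatic Nitrogen

A few compounds are considered here, and "the series" means these few. Any claim that something is new, unique, unknown or untested is made for them only; others in the source may bear on it.

Compound 1, `Cc1ccc(-n2cc(CNC(=O)c3cccc4c3cnn4C(C)C)nn2)c(C)c1`: > 40000 nM (a limit of the assay)
Compound 2, `CC(C)n1ncc2c(C(=O)NCc3cn(-c4ccc(I)cc4)nn3)cccc21`: > 40000 nM (a limit of the assay)
Compound 3, `CC(C)n1ncc2c(C(=O)NCc3cn(Cc4ccccc4)nn3)cccc21`: 13700 nM

All three values come from a functional assay on HepG2 cells (Homo sapiens) for inhibition, read by MTT assay, with a stated time of 72 h; a lower number here means a stronger inhibitor, a higher number a weaker inhibitor. Compound 1 stands at a limit, (the limit of > 40000 nM in this assay, at which 2 of the 3 values shown sit), so no number is known for it, only that it did not reach the measurable range. Compound 2 stands at the same limit. Compound 3, which carries a benzyl on the aromatic nitrogen, is the only one of the three with a real number in this assay, 13700 nM.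

The compound still to be measured is compound 4, `CC(C)n1ncc2c(C(=O)NCc3cn(Cc4ccc(C#N)cc4)nn3)cccc21`. Its change from compound 1 is 4-cyanobenzyl in place of 2,4-dimethylphenyl on an aromatic nitrogen. The measured step that bears most directly on it is an at least 2.9-fold lower number from compound 1 to compound 3 (0.46 log units; beyond the scatter), where benzyl also replaced 2,4-dimethylphenyl; the step of an at least 2.9-fold lower number from compound 2 to compound 3 (0.46 log units; beyond the scatter) runs the same way. Among the measured compounds shown here, compound 4 shares the benzyl of compound 3 and adds a nitrile, and no measured pair shows what that nitrile does on its own. Compound 4 is therefore expected to land near compound 3, which means an expected step of an at least 2.6-fold lower number from compound 1 to compound 4 (0.42 log units; beyond the scatter). The estimate for compound 4 is 15000 nM, with a range from 5000 nM to 40000 nM.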

Compound 4, half-maximal inhibitory concentration: > 40000 nM
Compound 4: only a limit was reported; the forecaster's own chance of this, stated with the estimate: 30%; middle value at least 2.6-fold (0.42 log units) from the limit.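

Within this assay, the cyano in place of hydrogen on an aromatic carbon of the benzyl gives an at least 2.9-fold higher number from compound 3 to compound 4 (0.46 log units; beyond the scatter). Among the compounds shown here, this is the first readable change made on the benzyl group itself, and it shows that a benzyl on the aromatic nitrogen does not by itself secure a measurable value, as compound 3, the only compound of the four with a real number, is lost to the limit once the nitrile is added. The steps from compound 1 and from compound 2 to compound 4 cannot be read, as both ends of each are limits and not numbers: the limit of > 40000 nM in this assay, at which 3 of the 4 values shown sit.

The compounds shown leave open whether this loss belongs to the nitrile in particular or would follow from any group on that carbon, such as a methyl, a chlorine or an amine. Also open, as far as these compounds go, are how far compound 4 really lies from compound 3, given that only a limit stands for it, and whether a phenethyl in place of the benzyl would keep a measurable value.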